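A few compounds are considered here, and "the series" means these few. Any claim that something is new, unique, unknown or untested is made for them only; others in the source may bear on it.

Measured compounds:
Compound 1 `CC[C@@H]1C(=O)N(C)c2cnc(Nc3ccc(S(N)(=O)=O)cc3)nc2N1C1CCCC1` — 5290 nM
Compound 2 `CC[C@@H]1C(=O)N(C)c2cnc(-n3ccc4cc(C(=O)NCC(C)C)ccc43)nc2N1C1CCCC1` — "not active" (no number reported)
Compound 3 `CCCCNC(=O)c1ccc2c(ccn2-c2ncc3c(n2)N(C2CCCC2)[C@H](CC)C(=O)N3C)c1` — 990 nM

The three compounds share one core and differ at the group attached to it. In a functional assay on NCI-H1975 cells (Homo sapiens) for antiproliferative activity, read by CCK-8 assay, with a stated time of 72 h (a higher number here means a weaker inhibitor of growth, a lower number a stronger inhibitor of growth), compound 1 gives 5290 nM, while compound 2 gives "not active" (no number reported), reported without a number. In this assay compound 3 gives 990 nM, the lowest of the two numbers; the gap from compound 3 to compound 1 is beyond the scatter, so compound 3 is the stronger inhibitor of growth of the two compounds with numbers.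

Compound 4 `CCNC(=O)c1ccc2c(ccn2-c2ncc3c(n2)N(C2CCCC2)[C@H](CC)C(=O)N3C)c1` is the next step from compound 3. The change is hydrogen in place of ethyl on a saturated chain carbon, two bonds along the chain from an amide-type nitrogen: on the amide side chain, butyl becomes ethyl. Going by the values given here, no measured pair shows this change, so its size is unknown. The chain is shortened by hydrogen in place of ethyl and nothing else moves. A small step is expected in this assay, toward a somewhat higher number, and it may well remain within the scatter. Compound 4 is therefore expected to give 1500 nM, between 500 nM and 5000 nM, which would mean an expected step of a 1.5-fold higher number from compound 3 to compound 4 (0.18 log units; within the scatter).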

Compound 4, concentration for 50% growth inhibition: 882 nM
Compound 4: the middle estimate sits 1.7-fold (0.23 log units) above what was measured, and the stated range covers the measured number.
By their numbers in this assay, from the lowest: compounds 4 and 3 (each within the scatter of the next); then compound 1.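

In this assay, going by these compounds alone, the change from butyl to ethyl on the amide side chain gives the first step that can be read between two measured compounds: a 1.1-fold lower number from compound 3 to compound 4 (0.05 log units; within the scatter). Hydrogen in place of ethyl at this saturated chain carbon, two bonds along the chain from an amide-type nitrogen, therefore removes two carbons without a difference that can be told from the scatter, so the longer butyl chain is not needed to keep this level of growth inhibition. Nothing measured here bears on why this step is so small.

From the compounds shown here alone, whether the same holds for a chain carrying an amine or a carboxylic acid, or for a chain longer than butyl, remains open. Compound 2 has no number, so how its branched chain compares with butyl or ethyl also cannot be read.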